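Replacing the acetyl on the ring nitrogen of compound 2

This account rests on a few compounds, and the source may have more. Where it says the series, first, only, none or still open, it means among the compounds named here.

Three compounds share a core in which an acrylic acid bearing an aryl group is attached to a fused two-ring system that carries a benzyloxy group and an acetyl on its ring nitrogen. Compound 1 `COc1cccc(/C(=C\c2cn(C(C)=O)c3ccc(OCc4ccccc4)cc23)C(=O)O)c1` gives 1080 nM in a functional assay on DU-145 cells (Homo sapiens) for cytotoxicity, read by MTT assay, with a stated time of 72 h; on this read-out lower numbers stand for stronger inhibition and higher numbers for weaker inhibition. Compound 2 `CC(=O)n1cc(/C=C(/C(=O)O)c2ccccc2)c2cc(OCc3ccccc3)ccc21` gives 26700 nM, and compound 3 `CC(=O)n1cc(/C=C(/C(=O)O)c2ccc(OCc3ccccc3)cc2)c2cc(OCc3ccccc3)ccc21` gives 1410 nM. Compound 2 is the least potent of the three: the step of a 25-fold higher number from compound 1 to compound 2 (1.39 log units; beyond the scatter) and the step of a 19-fold lower number from compound 2 to compound 3 (1.28 log units; beyond the scatter) both show large differences, so the aryl substituent on the acrylic acid matters strongly.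

Compound 4 `COc1ccc(Cn2cc(/C=C(/C(=O)O)c3ccccc3)c3cc(OCc4ccccc4)ccc32)cc1` differs from compound 2 by 4-methoxybenzyl in place of acetyl on an aromatic nitrogen. Neither measured step touches the ring nitrogen; both concern the aryl ring on the acrylic acid, so they give no direct guide to this change, only the sense that single substituent changes in this series can move the number a great deal. Within the data shown here, with no measured step on the nitrogen, the expectation for compound 4 is cautious: a moderate move toward a lower number is estimated, the step of a 2.7-fold lower number from compound 2 to compound 4 (0.43 log units; beyond the scatter), with wide uncertainty. Compound 4 is thus expected to give about 10000 nM, within the range 2500 nM to 40000 nM.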

Compound 4, half-maximal inhibitory concentration: 860 nM
Compound 4: the middle estimate sits 12-fold (1.07 log units) above what was measured, outside the stated range (below it).
By their numbers in this assay, from the lowest: compounds 4, 1 and 3 (each within the scatter of the next); then compound 2.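

In this assay, the change at the ring nitrogen gives a 31-fold lower number from compound 2 to compound 4 (1.49 log units; beyond the scatter), so this position, which neither earlier step touched, can move the number as strongly as the aryl ring on the acrylic acid. The entering 4-methoxybenzyl is larger than acetyl and brings a six-membered aromatic ring of carbon only, while the counts of hydrogen-bond donors and acceptors stay the same, so those counts do not separate the two groups. No measurement shown here explains why the number falls.

The compounds shown cannot tell whether the step depends on the aromatic ring of the new group, on its methoxy, or simply on the loss of acetyl, and a plain benzyl or a longer alkyl chain on the nitrogen would help to separate these possibilities. On these data alone, it also remains open whether 4-methoxybenzyl on the nitrogen would still lower the number when the aryl ring on the acrylic acid carries a methoxy or benzyloxy group, as the aryl ring does in the acetyl compounds with the lower numbers.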